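The source may hold more compounds than are shown below. What is called first, only, known or untested is meant among the compounds shown, and "the series" means these compounds.

Compound 1 `Cc1[nH]c2ccccc2c(=O)c1Cc1ccccc1`: > 40100 nM
Compound 2 `Cc1[nH]c2ccccc2c(=O)c1/C=C/c1ccccc1`: > 36300 nM
Compound 3 `Cc1[nH]c2ccc(Br)cc2c(=O)c1Br`: > 31500 nM

All three entries come from an ADME assay on J774 cells (Mus musculus) for cytotoxicity (on this read-out higher numbers stand for an effect only at larger amounts of compound and lower numbers for an effect already at smaller amounts), and all three are limits of the assay rather than numbers. Compound 1 therefore stands at a limit, as do the other two, so no order among the three can be read from them. Within the data shown here, no pair of measured compounds differs in one place only, which leaves no measured step to serve as a guide.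

Compound 4 `COc1ccc2[nH]c(C)c(Cc3ccccc3)c(=O)c2c1` is compound 1 with methoxy in place of hydrogen on an aromatic carbon. That carbon lies on a six-membered aromatic ring of carbon only, part of a fused or bridged system of two rings, meta to a fused ring and para to a fused ring.

In this assay, no shift beyond the scatter is expected from this change. The expectation starts from compound 1, whose limit is > 40100 nM. The expected step is an at least 1.1-fold lower number from compound 1 to compound 4 (0.04 log units; that floor lies within the scatter). For compound 4 the estimated value is 35800 nM, with an expected range from 15000 nM to 42000 nM. The most likely outcome is that the assay again reports only a limit.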

Compound 4, half-maximal effective concentration: > 23700 nM
Compound 4: a limit, no number (the forecaster's own chance of this, stated with the estimate: 85%); the middle value does not contradict the limit.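

In this assay compound 4 gives > 23700 nM, a limit of the assay and not a number. Among these compounds, compound 1 also stands at a limit, so no step from compound 1 to compound 4 can be read. The compounds shown leave open whether methoxy in place of hydrogen on an aromatic carbon shifts the read-out in this assay at all.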